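The compounds below may be only part of what the source reports. "The series", "measured", "known", "first", "only" and "open" are said of these compounds alone.

Compound 1, `COc1ncc(-c2ccc3c(c2)N(c2ccc(F)cc2)C(=O)CO3)cc1NS(=O)(=O)c1ccc(F)cc1`: 6500 nM
Compound 2, `O=C1COc2ccc(-c3cnc(Cl)c(NS(=O)(=O)c4ccc(F)cc4)c3)cc2N1c1ccc(F)cc1`: 22300 nM
Compound 3, `O=C1COc2ccc(-c3cnc(Cl)c(NS(=O)(=O)c4ccc(F)cc4)c3)cc2N1C1CC1`: 4330 nM

Of the compounds shown here, three have been measured in a functional assay on A549 cells (Homo sapiens) for antiproliferative activity, read by MTT assay, with a stated time of 72 h; a lower number here means a stronger inhibitor, a higher number a weaker inhibitor. Compound 1 gives 6500 nM, and compound 3 gives a number within the scatter of it, so the two cannot be told apart on these data. Compound 2 stands apart from both: the step of a 3.4-fold higher number from compound 1 to compound 2 (0.54 log units; beyond the scatter) lies beyond the scatter, and the step of a 5.2-fold lower number from compound 2 to compound 3 (0.71 log units; beyond the scatter) lies beyond the scatter as well. The unmeasured compound 4, `COc1ncc(-c2ccc3c(c2)N(c2ccc(Cl)cc2)C(=O)CO3)cc1NS(=O)(=O)c1ccc(F)cc1`, differs from compound 1 in one place: chloro in place of fluoro on an aromatic carbon. Neither measured step concerns this change. Within the data shown here, one exchanges methoxy for chloro on an aromatic carbon, the other exchanges 4-fluorophenyl for cyclopropyl on an amide-type nitrogen in a ring, so there is no direct precedent for fluoro giving way to chloro on the 4-fluorophenyl group. Without one, compound 4 is expected to sit close to compound 1, with a step of a 1.1-fold lower number from compound 1 to compound 4 (0.03 log units; within the scatter) that is expected to remain within the scatter. The estimate for compound 4 in this assay is 6000 nM, with a range from 2500 nM to 15000 nM.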

Compound 4, half-maximal inhibitory concentration: 8350 nM
For compound 4 the middle estimate is 1.4-fold (0.14 log units) below the measured one, within the range that was stated.
By their numbers in this assay, from the lowest: compounds 3, 1 and 4 (each within the scatter of the next); then compound 2.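

In this assay the change from 4-fluorophenyl to 4-chlorophenyl gives a 1.3-fold higher number from compound 1 to compound 4 (0.11 log units; within the scatter) and so leaves compound 1 and compound 4 indistinguishable. Among these compounds, this is the first reading at this position, on an aromatic carbon para to a large group, and it shows that this halogen exchange on the ring can be made without a readable difference on the methoxy-bearing compound. The earlier change on the same nitrogen was larger, replacing the whole 4-fluorophenyl with cyclopropyl, and on the chloro-bearing compounds it gave a 5.2-fold lower number from compound 2 to compound 3 (0.71 log units; beyond the scatter) beyond the scatter. No measurement shown here offers an explanation for this result.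

The compounds shown leave open whether an amine, a carboxylic acid or a trifluoromethyl at this position would also stay within the scatter. They also leave open whether 4-chlorophenyl behaves the same way on the chloro-bearing compounds.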